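A few compounds are considered here, and "the series" means these few. Any claim that something is new, unique, unknown or untested is made for them only; others in the source may bear on it.

Measured compounds:
compound 1 `CCn1cc(-c2nc3ccccc3[nH]2)c(=O)c2cc(F)c(N3CCNCC3)nc21`, 4800 nM
compound 2 `CCn1cc(-c2nc3ccccc3[nH]2)c(=O)c2cc(F)c(N3CCNC(C)C3)c(F)c21`, 11600 nM
compound 3 `CCn1cc(-c2nc3ccc([N+](=O)[O-])cc3[nH]2)c(=O)c2cc(F)c(N3CCNCC3)nc21`, 12400 nM

In a functional assay on A2780 cells (Homo sapiens) for cytotoxicity, read by MTT assay, with a stated time of 48 h (on this read-out lower numbers stand for stronger inhibition and higher numbers for weaker inhibition), compound 1 gives 4800 nM and compound 3 gives 12400 nM. Compound 3 arises from compound 1 by one change, (nitro in place of hydrogen on an aromatic carbon), and that change gave a 2.6-fold higher number from compound 1 to compound 3 (0.41 log units; beyond the scatter). Compound 2 gives 11600 nM in this assay; the difference between its core and the core of compound 1 is not broken down here. Compound 4 `CCn1cc(-c2nc3ccc([N+](=O)[O-])cc3[nH]2)c(=O)c2cc(F)c(N3CCNC(C)C3)c(F)c21` is not yet measured. It arises from compound 2 by the same change, (nitro in place of hydrogen on an aromatic carbon), the second occurrence of this change among the four compounds. Among the compounds with values here, a step of like size is expected from compound 2 to compound 4 in this assay, a 2.5-fold higher number from compound 2 to compound 4 (0.40 log units; beyond the scatter), because the single earlier example of the change gave a 2.6-fold higher number from compound 1 to compound 3 (0.41 log units; beyond the scatter); with one precedent the expectation is loosely held. Compound 4 is therefore estimated at 29000 nM, expected to fall between 12000 nM and 70000 nM.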

Compound 4, half-maximal inhibitory concentration: 2300 nM
Compound 4: the middle estimate sits 13-fold (1.10 log units) above what was measured; the whole stated range lies above it.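

In this assay the exchange of hydrogen for nitro does not carry over as a fixed step, and on the core of compound 2 the result is a drop in the number (a 5.0-fold lower number from compound 2 to compound 4 (0.70 log units; beyond the scatter)), against a rise on the core of compound 1 (a 2.6-fold higher number from compound 1 to compound 3 (0.41 log units; beyond the scatter)). The step therefore differs with the core, in direction as well as in size: the same change on two cores in this assay, a 2.6-fold higher number (0.41 log units; beyond the scatter) from compound 1 to compound 3 and a 5.0-fold lower number (0.70 log units; beyond the scatter) from compound 2 to compound 4, 13-fold (1.11 log units) apart, beyond the scatter of two such steps. This rests on one pair per core and does not show which part of the difference between the two cores goes with the reversal.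

Which part of that difference sets the direction of the step remains open. Also open, going by these compounds, is whether an amine or a carboxylic acid on the same aromatic carbon would differ between the two cores in the same way.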